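Working notes on a small series toward compound 4

The compounds below may be only part of what the source reports. "The series", "measured", "known", "first", "only" and "open" are said of these compounds alone.

Measured compounds in an assay on cells for inhibition of HSP60/HSP10 (Homo sapiens), with a stated time of 60 min; on this read-out higher numbers stand for weaker inhibition and lower numbers for stronger inhibition:
Compound 1 `Cc1ccc(S(=O)(=O)Nc2ccc3oc(-c4ccccc4)nc3c2)cc1` gives a limit of the assay, > 100000 nM.
Compound 2 `O=S(=O)(Nc1ccc2oc(-c3ccccc3)nc2c1)c1ccc(C(F)(F)F)cc1` gives a limit of the assay, > 100000 nM.
Compound 3 `Cc1ccccc1S(=O)(=O)Nc1ccc(-c2nc3ccccc3o2)cc1` gives 85000 nM.

Within the data shown here, of the three values, only that of compound 3 is a number; the other two are limits, as stated in the limit of > 100000 nM in this assay, at which 2 of the 3 values shown sit. Compound 1 and compound 2 differ by one change, (trifluoromethyl in place of methyl on an aromatic carbon), and the step that the two limits leave unreadable from compound 1 to compound 2 cannot be read, since both ends sit at the limit. Compound 3 is built from the same atoms as compound 1, joined differently; the difference between the two cores is not broken down here.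

Compound 4 `O=S(=O)(Nc1ccc(-c2nc3ccccc3o2)cc1)c1ccccc1C(F)(F)F` is not yet measured in this assay. It stands to compound 3 as compound 2 stands to compound 1, through (trifluoromethyl in place of methyl on an aromatic carbon). Among the measured compounds shown here, this is the same kind of change as the one from compound 1 to compound 2, but not the same: in compound 1 the affected carbon is para to a large group, in compound 3 it is ortho to a large group.

The expectation for compound 4 rests on the value of compound 3, 85000 nM, and on the unreadable step that the two limits leave unreadable from compound 1 to compound 2, which gives no direction for the change. The step from compound 3 to compound 4 is therefore expected to be small, a 1.3-fold higher number from compound 3 to compound 4 (0.11 log units; within the scatter), with a real chance that this assay returns only a limit. Compound 4 is estimated at 110000 nM, between 40000 nM and 300000 nM.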

Compound 4, half-maximal inhibitory concentration: 74000 nM
For compound 4 the middle estimate is 1.5-fold (0.17 log units) above the measured one, within the range that was stated.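

In this assay, trifluoromethyl in place of methyl on an aromatic carbon, ortho to a large group, gives a 1.1-fold lower number from compound 3 to compound 4 (0.06 log units; within the scatter), so on the core of compound 3 this change leaves no readable difference in the read-out. Among these compounds, the same kind of change on the core of compound 1 offers nothing to set beside this, since the step from compound 1 to compound 2 cannot be read and both of its ends are limits rather than numbers: the limit of > 100000 nM in this assay, at which 2 of the 4 values shown sit. The single readable step therefore rests on one pair on one core, and it does not show whether the change carries from one core to the other, in either direction or size.

Among the compounds shown, the changed carbon holds only methyl or trifluoromethyl, which leaves open whether an amine, a carboxylic acid or a longer chain such as ethyl in that place would give a step beyond the scatter in this assay. Also open, on these data alone, is whether any such group on the core of compound 1 would return a number instead of a limit, which would make a comparison between the two cores possible.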